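This account rests on a few compounds, and the source may have more. Where it says the series, first, only, none or still open, it means among the compounds named here.

Measured so far:
- compound 1, `COc1cc2c(Nc3ccc(C#N)cc3)ncnc2cc1OCCCN1CCN(C)CC1`, 13800 nM
- compound 2, `CCN1CCN(CCCOc2cc3ncnc(Nc4ccc(C#N)cc4)c3cc2OC)CC1`, 9580 nM
- compound 3, `COc1cc2c(Nc3ccccc3C#N)ncnc2cc1OCCCN1CCN(C)CC1`, 26400 nM

All three were run in a functional assay on HepG2 cells (Homo sapiens) for antiproliferative activity, read by MTT assay, with a stated time of 72 h; on this read-out lower numbers stand for stronger inhibition and higher numbers for weaker inhibition. Compound 1 and compound 2 share a core and differ by methyl in place of hydrogen on a saturated chain carbon bound to an amine nitrogen in a ring; the step is a 1.4-fold lower number from compound 1 to compound 2 (0.16 log units; within the scatter). Compound 1 and compound 3 differ in the core itself, by 2-cyanophenyl in place of 4-cyanophenyl on a nitrogen on an aromatic ring; the step is a 1.9-fold higher number from compound 1 to compound 3 (0.28 log units; within the scatter). Compound 3 gives the highest of the three numbers, but its step to compound 1 stays within the scatter, and only its gap to compound 2 lies beyond it, so no order among the three is claimed.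

Compound 4, `CCN1CCN(CCCOc2cc3ncnc(Nc4ccccc4C#N)c3cc2OC)CC1`, is not yet measured in this assay. It differs from compound 3 by methyl in place of hydrogen on a saturated chain carbon bound to an amine nitrogen in a ring, the same change as that from compound 1 to compound 2, made on the core of compound 3 rather than that of compound 1. Among the measured compounds shown here, the only precedent for this change is the step of a 1.4-fold lower number from compound 1 to compound 2 (0.16 log units; within the scatter), which stayed within the scatter, so a step of about the same size is expected, a 1.4-fold lower number from compound 3 to compound 4 (0.14 log units; within the scatter), with the caveat that a single pair on a different core is thin ground. On that basis the number for compound 4 in this assay is estimated at 19000 nM, expected to fall between 8000 nM and 45000 nM.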

Compound 4, half-maximal inhibitory concentration: 2110 nM
The estimate for compound 4 lay 9.0-fold (0.95 log units) above the measured number, and the stated range ends above it.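

In this assay, the change from 4-methylpiperazin-1-yl to 4-ethylpiperazin-1-yl gives a 13-fold lower number from compound 3 to compound 4 (1.10 log units; beyond the scatter), and its size does not carry over from the core of compound 1 to the core of compound 3: the same change on two cores in this assay, a 1.4-fold lower number (0.16 log units; within the scatter) from compound 1 to compound 2 and a 13-fold lower number (1.10 log units; beyond the scatter) from compound 3 to compound 4, 8.7-fold (0.94 log units) apart, beyond the scatter of two such steps. Seen from the other side, the change to 2-cyanophenyl gives a 4.5-fold lower number from compound 2 to compound 4 (0.66 log units; beyond the scatter) where 4-ethylpiperazin-1-yl is present, so this step also depends on the rest of the molecule: the same change on two cores in this assay, a 1.9-fold higher number (0.28 log units; within the scatter) from compound 1 to compound 3 and a 4.5-fold lower number (0.66 log units; beyond the scatter) from compound 2 to compound 4, 8.7-fold (0.94 log units) apart, beyond the scatter of two such steps. The two changes therefore do not add up independently across these four compounds, so a step measured on one core is a poor guide to the other, but with one pair per core this shows neither a general rule nor the reason for the difference.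

As far as these compounds go, it remains open whether the low number of compound 4 is particular to the ethyl group or would persist with 4-propylpiperazin-1-yl in its place. From the compounds shown here alone, it is also open whether the nitrile is needed, for instance against a chlorine at the same place on the phenyl ring.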